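Replacing methyl by pyridin-3-yl on the sulfanyl chain

The source may report more compounds than this note shows. Statements on the series, on what has been measured and on what is new or still open speak of the compounds shown alone.

Measured compounds:
compound 1 `COc1ccc(Nc2nccc(-c3cn(C4CCCC4)c4ccccc34)n2)c(OC)c1`: 1740 nM
compound 2 `CCSc1nc(C)c(-c2ccnc(Nc3ccc(OC)cc3OC)n2)s1`: 32400 nM
compound 3 `COc1ccc(N(C)c2nccc(-c3cn(C)c4ccccc34)n2)c(OC)c1`: 2000 nM

In a functional assay on MV4-11 cells (Homo sapiens) for inhibition, read by resazurin assay, with a stated time of 72 h (a lower number here means a stronger inhibitor of growth, a higher number a weaker inhibitor of growth), compound 2 gives 32400 nM, the highest of the three numbers; compound 3 gives 2000 nM and compound 1 gives 1740 nM, and both of these gaps to compound 2 lie beyond the scatter. Compound 4 `COc1ccc(Nc2nccc(-c3sc(SCc4cccnc4)nc3C)n2)c(OC)c1` has not yet been measured. It differs from compound 2 by pyridin-3-yl in place of methyl on a saturated chain carbon bound to a sulfur. For the measured compounds named here, no step between measured compounds matches this change, so the direction rests on nothing firmer than the size of the group entering. A moderate step toward a lower number, only somewhat beyond the scatter, is expected for a 3.2-fold lower number from compound 2 to compound 4 (0.51 log units; beyond the scatter). Compound 4 is therefore estimated at 10000 nM, within 2500 nM to 40000 nM.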

Compound 4, concentration for 50% growth inhibition: 270 nM
For compound 4 the middle estimate is 37-fold (1.57 log units) above the measured one; measured number outside the range, below it.
By their numbers in this assay, from the lowest: compound 4; then compounds 1 and 3 (each within the scatter of the next); then compound 2.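

In this assay the group on the sulfur proves far from indifferent: pyridin-3-yl in place of methyl on a saturated chain carbon bound to a sulfur gives a 120-fold lower number from compound 2 to compound 4 (2.08 log units; beyond the scatter) in a single change. For the compounds shown here, the earlier compounds offered no step at this position, so this is the first sign that it responds to substitution. Nothing measured here accounts for the gain. Still open, as far as these compounds go, is whether the ring nitrogen matters, which phenyl at this place would test, and whether a longer chain carrying pyridin-3-yl would keep the gain.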